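The compounds below may be only part of what the source reports. "The series", "measured", "known", "first", "only" and "open" are said of these compounds alone.

Compound 1 `C=C(C)C(=O)N(Cc1ccc(OC)c(O)c1)c1cc(OC)c(OC)c(OC)c1`: 200 nM
Compound 2 `COc1ccc(CNc2cc(OC)c(OC)c(OC)c2)cc1F`: 32200 nM

In a functional assay on HCT-116 cells (Homo sapiens) for inhibition, read by MTT assay, with a stated time of 48 h (on this read-out lower numbers stand for stronger inhibition and higher numbers for weaker inhibition), compound 1 gives 200 nM, the lower of the two numbers. Compound 2 gives 32200 nM, a gap beyond the usual scatter. Compound 3 `C=CC(=O)N(Cc1ccc(OC)c(O)c1)c1cc(OC)c(OC)c(OC)c1` differs from compound 1 by one change: hydrogen in place of methyl on a double-bonded chain carbon bound to a carbonyl carbon. Going by the values given here, no step between two measured compounds matches this change, so the expected step rests on the change alone. Compound 3 is expected to stay close to compound 1, with a step of a 1.3-fold lower number from compound 1 to compound 3 (0.12 log units; within the scatter) that lies within the scatter. The estimate for compound 3 is 150 nM, with a range from 50 nM to 500 nM.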

Compound 3, half-maximal inhibitory concentration: 98 nM
Compound 3: the middle estimate sits 1.5-fold (0.18 log units) above what was measured; the range from low to high includes it.
By their numbers in this assay, from the lowest: compound 3; then compound 1; then compound 2.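

The step of a 2.0-fold lower number from compound 1 to compound 3 (0.31 log units; beyond the scatter) in this assay is modest but lies beyond the scatter, and it shows that the methyl on the double-bonded chain carbon bound to a carbonyl carbon is not needed for this activity. The change from 1-methylethenyl to vinyl, which removes that single carbon, gives a lower number rather than a loss. Nothing available explains why the number moves.

The compounds shown leave open how an ethyl group, a longer chain or an amine on this same carbon would read. They also leave open whether the number would hold with propanoyl, the saturated counterpart of vinylcarbonyl.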